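Amide variation on a naphthyl hexafluoro-carbinol core

The source may hold more compounds than are shown below. What is called first, only, known or untested is meant among the compounds shown, and "the series" means these compounds.

Measured compounds:
Compound 1, `CCCC(=O)Nc1c(C(O)(C(F)(F)F)C(F)(F)F)ccc2ccccc12`: 131 nM
Compound 2, `C/C=C/C(=O)Nc1c(C(O)(C(F)(F)F)C(F)(F)F)ccc2ccccc12`: 72 nM
Compound 3, `CC(C)CCC(=O)Nc1c(C(O)(C(F)(F)F)C(F)(F)F)ccc2ccccc12`: 49 nM

Three amides sharing one core have been tested in an assay on LtK cells with ATP-sensitive inward rectifier potassium channel 11 (Homo sapiens) as the target; on this read-out lower numbers stand for an effect already at smaller amounts and higher numbers for an effect only at larger amounts of compound. Compound 2 sits in the middle of the three: the step of a 1.8-fold lower number from compound 1 to compound 2 (0.26 log units; within the scatter) and the step of a 1.5-fold lower number from compound 2 to compound 3 (0.17 log units; within the scatter) both stay within the scatter, so the three values are not clearly separated, though the longer step of a 2.7-fold lower number from compound 1 to compound 3 (0.43 log units; beyond the scatter) does reach beyond it. The piece now follows compound 2 to compound 4, `COc1cccc(C(=O)Nc2c(C(O)(C(F)(F)F)C(F)(F)F)ccc3ccccc23)c1`, in which (3-methoxyphenyl in place of prop-1-en-1-yl on a carbonyl carbon). For the measured compounds named here, no measured step replaces an open chain on the carbonyl carbon with an aromatic ring, so no direct precedent exists; the steps that bear on it are only those above, which show that changing the group on the carbonyl carbon has shifted the value little. Compound 4 is therefore expected to give 65 nM, within a range of 20 nM to 220 nM, a step of a 1.1-fold lower number from compound 2 to compound 4 (0.04 log units; within the scatter) that is expected to remain within the scatter.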

Compound 4, half-maximal effective concentration: 185 nM
For compound 4 the middle estimate is 2.8-fold (0.45 log units) below the measured one, and the stated range covers the measured number.
By their numbers in this assay, from the lowest: compounds 3, 2, 1 and 4 (each within the scatter of the next, the first and the last beyond it).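

In this assay, the group on the carbonyl carbon proves able to move the value beyond the scatter when 3-methoxyphenyl replaces an open chain: the result is a 2.6-fold higher number from compound 2 to compound 4 (0.41 log units; beyond the scatter) and a 3.8-fold higher number from compound 3 to compound 4 (0.58 log units; beyond the scatter). Against the propyl amide, however, the same replacement gives a 1.4-fold higher number from compound 1 to compound 4 (0.15 log units; within the scatter), so compound 4 is not separated from compound 1. The aromatic ring therefore gives no lower number than any of the three open chains shown, and it is clearly separated only from the prop-1-en-1-yl and isopentyl amides.

Nothing available explains why the number rises with this ring. An unsubstituted phenyl or a cyclohexyl on the carbonyl carbon would show whether the higher number goes with the ring itself or with its methoxy group.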